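The source may hold more compounds than are shown below. What is called first, only, known or untested is meant among the compounds shown, and "the series" means these compounds.

Measured in an ADME assay on RAW264.7 cells (Mus musculus) for cytotoxicity, read by MTT assay, with a stated time of 24 h, in the presence of a further agent that is not named here; a higher number here means a weaker inhibitor, a lower number a stronger inhibitor:
- compound 1 `O=C1OC(Cc2nc(-c3ccc(Oc4ccccc4)cc3)no2)c2ccccc21`: > 40000 nM
- compound 2 `CCCOc1ccc(C(O)C2OC(=O)c3c(OC)cc(OC)cc32)cc1`: > 40000 nM

Each entry is a limit of the assay and not a number: the limit of > 40000 nM in this assay, at which 2 of the 2 values shown sit. Compound 2 therefore stands at that limit, with no number to its name. Compound 3 `CCOCCOc1ccc(C(O)C2OC(=O)c3c(OC)cc(OC)cc32)cc1` differs from it by one change, propoxy to 2-ethoxyethoxy: ethoxy in place of methyl on a saturated chain carbon, two bonds along the chain from an oxygen on an aromatic ring. Going by the values given here, no measured step in this assay bears on this change, so no step beyond the scatter is expected, in either direction. Compound 3 is expected at 45000 nM, with an estimated range of 25000 nM to 80000 nM, and a further reading at the limit is likely.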

Compound 3, half-maximal inhibitory concentration: > 40000 nM
Compound 3: a limit, no number (the forecaster's own chance of this, stated with the estimate: 85%); the middle value lies beyond the limit too.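

No new step can be read between compound 2 and compound 3, because both values are limits and not numbers: the limit of > 40000 nM in this assay, at which 3 of the 3 values shown sit.
The compounds shown leave open how propoxy and 2-ethoxyethoxy compare within the measurable range.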